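The compounds below may be only part of what the source reports. "The series", "measured", "known", "first", "only" and "open" are said of these compounds alone.

Working notes on the sulfonamide hydrazide series.

Three compounds have numbers in an ADME assay on MCF-10A cells (Homo sapiens) for antiproliferative activity, read by MTT assay; a lower number here means a stronger inhibitor, a higher number a weaker inhibitor. Compound 1 `C/C(=N/NC(=O)c1ccc(S(N)(=O)=O)cc1)c1ccc(Br)cc1` gives 37600 nM. Compound 2 `C/C(=N/NC(=O)c1ccc(S(N)(=O)=O)cc1)c1ccc(Cl)cc1` gives 62700 nM. Compound 3 `NS(=O)(=O)c1ccc(C(=O)N/N=C\c2ccc(Br)cc2)cc1` gives 27700 nM. Compounds 1 and 2 share one core and differ in a single place, (chloro in place of bromo on an aromatic carbon); that change moved the number a 1.7-fold higher number from compound 1 to compound 2 (0.22 log units; within the scatter). Compound 3 carries a different core from compound 1, and the difference between the two cores is not broken down here; their two values lie within the scatter of each other, so no order between them is claimed. Against compound 2 the number of compound 3 is lower by more than the scatter.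

Compound 4 `NS(=O)(=O)c1ccc(C(=O)N/N=C\c2ccc(Cl)cc2)cc1` is not yet measured. It stands to compound 3 exactly as compound 2 stands to compound 1: the change is chloro in place of bromo on an aromatic carbon, and the place is the same in both pairs, so this is the same change on a second core. Among the compounds with values here, the expectation for compound 4 rests on the one measured instance of this change, because a 1.7-fold higher number from compound 1 to compound 2 (0.22 log units; within the scatter) was within the scatter, the step from compound 3 to compound 4 is expected to be of similar size, a 1.7-fold higher number from compound 3 to compound 4 (0.23 log units; within the scatter), with wide uncertainty since only one precedent exists and the two cores differ. Compound 4 is therefore estimated at 47000 nM, with a plausible range from 24000 nM to 95000 nM.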

Compound 4, half-maximal inhibitory concentration: 82000 nM
Compound 4: the middle estimate sits 1.7-fold (0.24 log units) below what was measured; measured number inside the range.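

In this assay, chloro in place of bromo on the second core gives a 3.0-fold higher number from compound 3 to compound 4 (0.47 log units; beyond the scatter), so on this core the 4-chlorophenyl compound carries the higher number by more than the scatter. Set beside the earlier step, the change runs in the same direction on both cores and the two steps cannot be told apart in size, so what was seen on the first core carries over to the second as far as these pairs can show: the same change on two cores in this assay, a 1.7-fold higher number (0.22 log units; within the scatter) from compound 1 to compound 2 and a 3.0-fold higher number (0.47 log units; beyond the scatter) from compound 3 to compound 4, 1.8-fold (0.25 log units) apart, within the scatter of two such steps. Within the data shown here, this does not show that the change costs more on one core than on the other, and it does not fix a size for the step, since only two pairs exist and the earlier step alone lies within the scatter.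

The compounds shown hold only bromo and chloro at this place, so it remains open whether the same ordering would extend to a fluoro group, a methoxy group or an amine there. Going by these compounds, how the two cores compare for other groups at this place also remains open, as does whether the step would hold on a third core.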